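Amide side chain change from compound 3 to compound 4

The source may report more compounds than this note shows. Statements on the series, on what has been measured and on what is new or still open speak of the compounds shown alone.

Measured so far in an in vitro ADME assay on microsomes from Gut (Homo sapiens) for metabolic stability, using NADPH; on this read-out lower numbers stand for slow clearance and higher numbers for fast clearance (all three values are limits):
compound 1 `COc1ccc(OC(F)(F)F)cc1Cn1c(C(=O)NCC(C)(C)CO)cc2cc(C#N)ccc21` | < 6 mL.min-1.g-1
compound 2 `COc1ccc(C(C)(C)C)cc1Cn1c(C(=O)NCC2(CO)CC2)cc2cc(C#N)ccc21` | < 6 mL.min-1.g-1
compound 3 `CC(O)CCNC(=O)c1cc2cc(C#N)ccc2n1Cc1cccc(OC(F)(F)F)c1` | < 6 mL.min-1.g-1

Compound 3 reads < 6 mL.min-1.g-1 in this assay and this is a limit, not a number. Among the measured compounds shown here, the series so far offers only the limit of < 6 mL.min-1.g-1 in this assay, at which 3 of the 3 values shown sit, and contains no measured step between compounds that differ in one place.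

Compound 4 `CC(O)C1(CNC(=O)c2cc3cc(C#N)ccc3n2Cc2cccc(OC(F)(F)F)c2)CCCC1` has not yet been measured. Its difference from compound 3 lies on a saturated chain carbon bound to an amide-type nitrogen: a group of 8 heavy atoms (7 carbon, 1 oxygen; one five-membered non-aromatic ring of carbon only) in place of a group of 4 heavy atoms (3 carbon, 1 oxygen; no ring), on a saturated chain carbon bound to an amide-type nitrogen.

The expectation rests first on compound 1, whose different amide side chain still leaves it at the limit < 6 mL.min-1.g-1 in this assay. It rests also on compound 2, which has another amide side chain and likewise sits at the limit < 6 mL.min-1.g-1 in the same measurement. No change beyond the usual scatter is expected in this assay, and the estimated step of a number no lower from compound 3 to compound 4 (the limit leaves the size open) is a working figure, with any drift expected towards faster clearance. For compound 4 the expected value is 6 mL.min-1.g-1, with an estimated range from 3 mL.min-1.g-1 to 15 mL.min-1.g-1 and another reading at the limit quite possible.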

Compound 4, intrinsic clearance in microsomes: 99 mL.min-1.g-1
For compound 4 the middle estimate is 17-fold (1.22 log units) below the measured one; the whole stated range lies below it.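

In this assay, the amide side chain on a saturated chain carbon bound to an amide-type nitrogen proves to be a place where the read-out can move sharply: exchanging the 2-hydroxypropyl group for the larger group with a five-membered non-aromatic carbon ring gives an at least 16-fold higher number from compound 3 to compound 4 (1.21 log units; beyond the scatter). The reading for compound 3, < 6 mL.min-1.g-1, is a limit and not a number. Compound 4 is the one compound shown that stands off this limit, and the series now holds its first step between compounds that differ in one place, where the earlier values offered only a shared reading: the limit of < 6 mL.min-1.g-1 in this assay, at which 3 of the 4 values shown sit.

This single step does not separate the contribution of the five-membered carbon ring from that of the larger heavy-atom count, and it does not show whether the same exchange would carry the same step on the core of compound 1 or compound 2. It also leaves open how this place would read with a longer open chain without a ring, or with an amine or a carboxylic acid in place of the hydroxyl group.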